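The source may report more compounds than this note shows. Statements on the series, on what has been measured and on what is new or still open speak of the compounds shown alone.

Measured compounds:
compound 1, `Cc1cc(C)c2cccc(OCc3c(Cl)ccc(S(=O)(=O)NC4(C(=O)N5CCN(C(=O)C[C@@H](N)CCCN)CC5)CCCC4)c3Cl)c2n1`
compound 2, `Cc1cc(C)c2cccc(OCc3c(Cl)ccc(S(=O)(=O)NC4(C(=O)N5CCN(C(=O)C[C@H](CCCN)[N+](C)(C)C)CC5)CCCC4)c3Cl)c2n1`

In an assay on isolated protein for binding affinity to B1 bradykinin receptor (Homo sapiens) (a higher number here means a weaker inhibitor, a lower number a stronger inhibitor), compound 1 gives < 10000 nM, which is a limit of the assay and not a number. In this assay compound 2 gives < 10000 nM, likewise a limit and not a number. Both values sit at the limit of < 10000 nM in this assay, at which 2 of the 2 values shown sit, so compound 2 stands only at that limit, with no number that would place it against compound 1. Among the compounds with values here, the one measured step, a step that the two limits leave unreadable from compound 1 to compound 2, is on a saturated chain carbon bound to two saturated chain carbons, and its size cannot be read from the two limits.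

Compound 3, `Cc1cc(C)c2cccc(OCc3c(Cl)ccc(S(=O)(=O)NC4(C(=O)N5CCN(C(=O)CCC[N+](C)(C)C)CC5)CCCC4)c3Cl)c2n1`, differs from compound 2 by a group of 6 heavy atoms (5 carbon, 1 nitrogen; no ring) in place of a group of 9 heavy atoms (7 carbon, 2 nitrogen; no ring), on a saturated chain carbon bound to a carbonyl carbon. Within the data shown here, the only recorded step bears on the same chain but yields no readable size, so it gives neither size nor direction for this assay. With both measured values at the limit, the step is expected to be a step that the limit leaves unreadable from compound 2 to compound 3. Compound 3 is therefore estimated to give 3000 nM in this assay, with a range from 300 nM to 10000 nM, and a real chance that only the limit is reported again.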

Compound 3, inhibition constant: < 10000 nM
Compound 3: no number, only a limit; the forecaster's own chance of this, stated with the estimate: 60%; the middle value lies beyond the limit too.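

In this assay compound 3 gives < 10000 nM, a limit of the assay and not a number. No step among compound 1, compound 2 and compound 3 can therefore be read: the limit of < 10000 nM in this assay, at which 3 of the 3 values shown sit.

The compounds shown leave open how these three rank in this assay, and what size or direction any of the chain changes has.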